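Hydrazone aryl swap: compound 2 to compound 3

This account rests on a few compounds, and the source may have more. Where it says the series, first, only, none or still open, it means among the compounds named here.

In a functional assay on NCI-H460 cells (Homo sapiens) for cytotoxicity, read by MTT assay, with a stated time of 72 h (a higher number here means a weaker inhibitor, a lower number a stronger inhibitor), compound 2 `CN(C)CCn1cnnc1-c1cc(Oc2ccc(NC(=O)N/N=C/c3c[nH]c4ccccc34)cc2F)ccn1` gives 1630 nM, the higher of the two numbers in hand; compound 1 `CN(C)CCn1cnnc1-c1cc(Oc2ccc(NC(=O)N/N=C/c3ccc(Cl)cc3)cc2F)ccn1` gives 320 nM. Compound 3 `COc1ccc(/C=N/NC(=O)Nc2ccc(Oc3ccnc(-c4nncn4CCN(C)C)c3)c(F)c2)c(OC)c1` is not yet measured and differs from compound 2 at one site: 2,4-dimethoxyphenyl in place of 1H-indol-3-yl on a carbon with a double bond to nitrogen. Going by the values given here, the only step that bears on this site is a 5.1-fold higher number from compound 1 to compound 2 (0.71 log units; beyond the scatter). Since the group entering compound 3 is again one six-membered aromatic ring of carbon only, a step back toward the number of compound 1 is expected rather than none. For compound 3 the estimate in this assay is 500 nM, with a range of 150 nM to 2000 nM. The expected step is a 3.3-fold lower number from compound 2 to compound 3 (0.51 log units; beyond the scatter).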

Compound 3, half-maximal inhibitory concentration: 1570 nM
For compound 3 the middle estimate is 3.1-fold (0.50 log units) below the measured one; measured number inside the range.
By their numbers in this assay, from the lowest: compound 1; then compounds 3 and 2 (each within the scatter of the next).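

In this assay, swapping 1H-indol-3-yl for 2,4-dimethoxyphenyl on a carbon with a double bond to nitrogen leaves the two compounds indistinguishable (a 1.0-fold lower number from compound 2 to compound 3 (0.02 log units; within the scatter)). A six-membered aromatic ring of carbon only does not by itself restore the level of compound 1 (a 4.9-fold higher number from compound 1 to compound 3 (0.69 log units; beyond the scatter)), so 4-chlorophenyl alone stands apart among the three groups. Nothing available explains this difference between the groups.

Open, from the compounds shown here alone, is whether a 4-bromophenyl or a 4-aminophenyl group on this carbon would fall with compound 1 or with compound 3. Also open, going by these compounds, is whether an unsubstituted phenyl group would separate the effect of the ring's substituents from that of the ring itself.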